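The source may hold more compounds than are shown below. What is called first, only, known or untested is meant among the compounds shown, and "the series" means these compounds.

Compounds measured in an assay on HeLa cells for inhibition of Indoleamine 2,3-dioxygenase 1 (Homo sapiens), read by spectrophotometry, with a stated time of 24 h; a lower number here means that less compound is needed, a higher number that more compound is needed for the effect:
compound 1, `CC(=O)Nc1ccc(S(=O)(=O)NNc2ccccc2)cc1`: > 10000 nM
compound 2, `CC(=O)Nc1ccc(S(=O)(=O)NNc2ccc(F)cc2)cc1`: 609 nM

The value of compound 1 is a limit of the assay, (the limit of > 10000 nM in this assay, at which 1 of the 2 values shown sits). Compound 2 therefore holds the only number shown in this assay. Among the compounds with values here, the single measured step, an at least 16-fold lower number from compound 1 to compound 2 (1.21 log units; beyond the scatter), concerns fluoro in place of hydrogen. Compound 3, `CC(=O)Nc1ccc(S(=O)(=O)NNc2ccc(Cl)cc2)cc1`, differs from compound 2 by chloro in place of fluoro on an aromatic carbon. Within the data shown here, no measured pair separates fluoro from chloro, so that step bears on this change only loosely. The expected step is a 1.5-fold lower number from compound 2 to compound 3 (0.18 log units; within the scatter), within the scatter. Compound 3 is estimated at 400 nM, with a range from 150 nM to 1200 nM.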

Compound 3, half-maximal effective concentration: 142 nM
Estimate against measurement, compound 3: 2.8-fold (0.45 log units) above; the measured number lies below the stated range.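

In this assay, the identity of the halogen on this aromatic carbon, para to a large group, matters as well as its presence: chloro in place of fluoro gives a 4.3-fold lower number from compound 2 to compound 3 (0.63 log units; beyond the scatter). Measured from hydrogen, chloro gives an at least 70-fold lower number from compound 1 to compound 3 (1.84 log units; beyond the scatter). The value of compound 1 is a limit of the assay, so this step is a bound: the limit of > 10000 nM in this assay, at which 1 of the 3 values shown sits.

As far as these compounds go, what bromo, methoxy or an amine would give at this place remains open. From the compounds shown here alone, whether chloro keeps its lead over fluoro elsewhere on this ring is also open.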